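The source may report more compounds than this note shows. Statements on the series, on what has been measured and on what is new or still open speak of the compounds shown alone.

Working notes on the series. Compound 1 `c1ccc2c(c1)CN[C@@H](CN(CCCCNC1CCCCC1)[C@H]1CCCc3cccnc31)C2` is measured in a functional assay on cells for antagonist activity at C-X-C chemokine receptor type 4 (Homo sapiens), read by fluorescence and calcium flux, with stated times of 25 min and 90 s; on this read-out higher numbers stand for weaker inhibition and lower numbers for stronger inhibition; in that assay compound 1 gives 75.2 nM. Among the measured compounds shown here, compound 2 `CC1(C)CCC(NCc2ccc(CN(C[C@H]3Cc4ccccc4CN3)[C@H]3CCCc4cccnc43)cc2)CC1`, the only other measured member, gives 661 nM in this assay. Of the two numbers, compound 1 stands lowest, and the gap to compound 2 is beyond the usual scatter of repeats. For the measured compounds named here, no step between measured compounds that differ in one place is available, so the direction of any single change is untested.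

Compound 3 `C(=C/CN(C[C@H]1Cc2ccccc2CN1)[C@H]1CCCc2cccnc21)\CNCc1ccccn1` is not yet measured. Relative to compound 1 the change is a group of 11 heavy atoms (9 carbon, 2 nitrogen; one six-membered aromatic ring with 1 hetero atom) in place of a group of 10 heavy atoms (9 carbon, 1 nitrogen; one six-membered non-aromatic ring of carbon only), on a saturated chain carbon bound to an amine nitrogen. The cyclohexylamino end is exchanged for a pyridine-bearing amine on an unsaturated chain, with no comparable change measured here. A small step is expected, toward a higher number but not clearly beyond the scatter; compound 3 is estimated to give 130 nM with a range of 35 nM to 500 nM, which means an expected 1.7-fold higher number from compound 1 to compound 3 (0.24 log units; within the scatter) in this assay.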

Compound 3, half-maximal inhibitory concentration: 58.3 nM
For compound 3 the middle estimate is 2.2-fold (0.35 log units) above the measured one, and the stated range covers the measured number.
By their numbers in this assay, from the lowest: compounds 3 and 1 (each within the scatter of the next); then compound 2.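

In this assay, exchanging the 3-(cyclohexylamino)propyl group for the group bearing a six-membered aromatic ring with 1 hetero atom and a double bond outside that ring, on a saturated chain carbon bound to an amine nitrogen, gives a 1.3-fold lower number from compound 1 to compound 3 (0.11 log units; within the scatter). This first step at this position therefore shows that the non-aromatic carbon ring and its chain can be replaced without a shift beyond the scatter, though this rests on a single pair. Nothing available explains this outcome.

The ring and the chain change together in this step, so their separate contributions cannot be told apart. Going by these compounds, it remains open how the read-out would respond to a morpholine or piperidine ring at the chain end, or to the same pyridine-bearing amine on a fully saturated chain.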